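This account rests on a few compounds, and the source may have more. Where it says the series, first, only, none or still open, it means among the compounds named here.

Measured so far in an assay on cell membranes for displacement of a labelled ligand from Sigma non-opioid intracellular receptor 1 (Cavia porcellus), read by scintillation counting; a lower number here means a stronger inhibitor, a higher number a weaker inhibitor:
- compound 1, `COc1cc2c(cc1C(C)N[C@H](C)c1ccccc1)C=CC(C)(C)O2`, gives 232 nM
- compound 2, `CCNC(C)c1cc2c(cc1OC)OC(C)(C)C=C2`, gives 83 nM
- compound 3, `COc1cc2c(cc1C(C)NCCCCc1ccccc1)CCC(C)(C)O2`, gives 115 nM

For the measured compounds named here, the one single-point step among the measured compounds is the change (hydrogen in place of phenyl on a saturated chain carbon bound to an amine nitrogen and a saturated chain carbon), and it gave a 2.8-fold lower number from compound 1 to compound 2 (0.45 log units; beyond the scatter). Compound 3 sits close to both: its value against compound 2 and against compound 1 falls within the usual scatter, so no order among these three is claimed. The cores of compound 1 and compound 3 differ in more than one place, and that difference is not broken down here.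

Compound 4, `CCCCNC(C)c1cc2c(cc1OC)OC(C)(C)CC2`, is not yet measured. It differs from compound 3 by hydrogen in place of phenyl on a saturated chain carbon, four bonds along the chain from an amine nitrogen. Going by the values given here, this is the same kind of change as the one from compound 1 to compound 2, but not the same: there the hydrogen replaced the phenyl on a saturated chain carbon bound to an amine nitrogen and a saturated chain carbon, whereas here it is on a saturated chain carbon, four bonds along the chain from an amine nitrogen. With only one measured occurrence, and that on a different core and at a different place, the expectation rests loosely on the step of a 2.8-fold lower number from compound 1 to compound 2 (0.45 log units; beyond the scatter) and on compound 2 giving 83 nM as a phenyl-free comparator. For compound 4 a step of a 1.8-fold lower number from compound 3 to compound 4 (0.25 log units; within the scatter) is expected. The estimate for compound 4 is 65 nM, with the likely range 25 nM to 180 nM.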

Compound 4, inhibition constant: 43 nM
Compound 4: middle estimate off by 1.5-fold (0.18 log units), on the high side; the range from low to high includes it.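

In this assay, hydrogen in place of phenyl on a saturated chain carbon, four bonds along the chain from an amine nitrogen, gives a 2.7-fold lower number from compound 3 to compound 4 (0.43 log units; beyond the scatter). Set beside the earlier step, removal of the phenyl carries over from one core to the other with no difference in size beyond the scatter: the same change on two cores in this assay, a 2.8-fold lower number (0.45 log units; beyond the scatter) from compound 1 to compound 2 and a 2.7-fold lower number (0.43 log units; beyond the scatter) from compound 3 to compound 4, 1.0-fold (0.02 log units) apart, within the scatter of two such steps

This rests on only two occurrences, with the phenyl at a different place on the chain in each, so it does not show that the step would hold on a further core or at another place on the chain, and it gives no reason for the lower numbers.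

Left open is whether a chain end other than plain phenyl, such as a fluorophenyl, a pyridine ring or a cyclohexyl ring, would behave as phenyl does here, and how a propyl chain or a longer alkyl chain would compare with the butyl chain of compound 4. Also open, on these data alone, is what a tertiary amine or an amide in place of the secondary amine would do to the number in this assay.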